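The compounds below may be only part of what the source reports. "The series", "measured", "known", "first", "only" and "open" are said of these compounds alone.

In an ADME assay on RAW264.7 cells (Mus musculus) for cytotoxicity, read by MTT assay (a higher number here means a weaker inhibitor, a lower number a stronger inhibitor), the measurements so far are:
- compound 1 `O=C(/C=C/C=C/c1ccc(Cl)cc1)c1cc(Cl)ccc1O` gives "not determined" (no result reported)
- compound 2 `COc1cc(/C=C/C=C/C(=O)c2ccccc2)cc(OC)c1O` gives 28700 nM

For the measured compounds named here, compound 2 therefore holds the only number, and nothing yet shows where it ranks. Compound 3 `COc1cc(/C=C/C=C/C(=O)c2ccc(F)cc2)cc(OC)c1O` departs from compound 2 by a single change (fluoro in place of hydrogen on an aromatic carbon), fluoro in place of hydrogen on an aromatic carbon. Going by the values given here, no measured step exists to size this change, so the expectation rests on compound 2 alone (28700 nM): no shift beyond the usual scatter in this assay, in either direction. The expected step (a 1.1-fold lower number from compound 2 to compound 3 (0.04 log units; within the scatter)) is correspondingly small. For compound 3 the estimated value is 26000 nM, within an expected range from 10000 nM to 65000 nM.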

Compound 3, half-maximal inhibitory concentration: 5000 nM
Compound 3: middle estimate off by 5.2-fold (0.72 log units), on the high side; the whole stated range lies above it.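

In this assay, the change from phenyl to 4-fluorophenyl, with fluoro in place of hydrogen on an aromatic carbon para to a large group, gives a 5.7-fold lower number from compound 2 to compound 3 (0.76 log units; beyond the scatter). This position therefore responds to even this single-atom change, which compound 2 alone could not show. Nothing at hand accounts for the shift.

For the compounds shown here, with only this one step, it remains open whether an amine, a carboxylic acid or trifluoromethyl at the same place would lower the number further or raise it. On these data alone, whether the step holds in the core of compound 1 also remains open.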